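This account rests on a few compounds, and the source may have more. Where it says the series, first, only, none or still open, it means among the compounds named here.

Measured so far in a functional assay on T47D cells (Homo sapiens) for cytotoxicity, read by MTT assay, with a stated time of 3 h; on this read-out lower numbers stand for stronger inhibition and higher numbers for weaker inhibition:
compound 1 `Cc1ccc(-c2csc(NC(=O)CN3CCN(c4cc(=O)n(-c5ccccc5)c5ccccc45)CC3)n2)cc1` gives 16500 nM
compound 2 `O=C(CN1CCN(c2cc(=O)n(-c3ccccc3)c3ccccc23)CC1)Nc1nc(-c2ccc(Cl)cc2)cs1` gives 30200 nM
compound 3 `COc1ccc(-c2csc(NC(=O)CN3CCN(c4cc(=O)n(-c5ccccc5)c5ccccc45)CC3)n2)cc1` gives 8110 nM

With the lowest number of the three, compound 3 (8110 nM) is the strongest so far in this assay and the next question is what its methoxy contributes. Compound 4 `O=C(CN1CCN(c2cc(=O)n(-c3ccccc3)c3ccccc23)CC1)Nc1nc(-c2ccccc2)cs1` has hydrogen in place of methoxy on an aromatic carbon, para to a large group (hydrogen in place of methoxy on an aromatic carbon), which turns 4-methoxyphenyl into phenyl.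

Among the compounds with values here, two measured steps bear most directly on this, and both favour methoxy (a 2.0-fold lower number from compound 1 to compound 3 (0.31 log units; beyond the scatter)) and (a 3.7-fold lower number from compound 2 to compound 3 (0.57 log units; beyond the scatter)). The methyl and chloro compounds themselves differ little (a 1.8-fold higher number from compound 1 to compound 2 (0.26 log units; within the scatter)). Within the data shown here, no measured compound has hydrogen at this place, so the comparison is indirect. Removing methoxy is therefore expected to raise the number by a modest amount, similar in size to the steps from the other two groups (a 2.1-fold higher number from compound 3 to compound 4 (0.32 log units; beyond the scatter)). For compound 4 the estimated value is 17000 nM (expected range 7500 nM to 38000 nM).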

Compound 4, half-maximal inhibitory concentration: 10300 nM
Estimate against measurement, compound 4: 1.7-fold (0.22 log units) above; the measured number falls inside the stated range.
By their numbers in this assay, from the lowest: compounds 3, 4, 1 and 2 (each within the scatter of the next, the first and the last beyond it).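

With hydrogen now at this position, methoxy proves not to be needed in this assay, since replacing it gives only a small step that stays within the scatter (a 1.3-fold higher number from compound 3 to compound 4 (0.10 log units; within the scatter)). Methyl also cannot be told apart from hydrogen (a 1.6-fold lower number from compound 1 to compound 4 (0.20 log units; within the scatter)), whereas chloro does separate from it (a 2.9-fold lower number from compound 2 to compound 4 (0.47 log units; beyond the scatter)), so among these four compounds chloro stands out from hydrogen, while the gap between methyl and methoxy, though just beyond the scatter, is not matched by either group's step from hydrogen. Nothing available here explains why chloro behaves differently.

Going by these compounds, whether an amine, a carboxylic acid or a fluorine atom at this position would move the number clearly away from that of hydrogen remains open. Also open, on these data alone, is whether these small differences would hold if the shared core were changed elsewhere.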